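Swapping chloro for methylsulfanyl: solubility of compound 4

This account rests on a few compounds, and the source may have more. Where it says the series, first, only, none or still open, it means among the compounds named here.

Measured so far:
- compound 1, `CCOC(=O)C1=C(C)N/C(=C/c2cc(C)n(-c3cccc(C(F)(F)F)c3)c2C)C1=O`: 2.1 ug/mL
- compound 2, `CCOC(=O)C1=C(C)N/C(=C/c2cc(C)n(-c3ccc(Cl)cc3)c2C)C1=O`: 1.6 ug/mL
- compound 3, `CCOC(=O)C1=C(C)N/C(=C/c2cc(C)n(-c3ccc(SC(F)(F)F)cc3)c2C)C1=O`: 1 ug/mL

All three compounds share the same core and differ only in the aromatic group carried on the ring nitrogen. In a physicochemical assay for solubility, read by nephelometry, in phosphate buffer, measured as kinetic solubility, at pH 6.5 (on this read-out higher numbers stand for higher solubility and lower numbers for lower solubility), compound 2 gives 1.6 ug/mL. Among the three, compound 2 stands second highest, but its gaps to both neighbours are small: a 1.3-fold lower number from compound 1 to compound 2 (0.12 log units; within the scatter), and a 1.6-fold lower number from compound 2 to compound 3 (0.20 log units; within the scatter). Neither step is large enough to count as a real difference.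

Compound 4, `CCOC(=O)C1=C(C)N/C(=C/c2cc(C)n(-c3ccc(SC)cc3)c2C)C1=O`, is not yet measured. It differs from compound 2 in one place: methylsulfanyl in place of chloro on an aromatic carbon. The closest guide is the step from compound 2 to compound 3, where chloro gave way to (trifluoromethyl)sulfanyl and the number moved only within the scatter. The methylsulfanyl group is a smaller variation of that same kind of change, so no step beyond the scatter is expected in this assay.

Compound 4 is therefore estimated to land close to compound 2, at 1.8 ug/mL, with a range from 0.8 ug/mL to 4 ug/mL, which means an expected step of a 1.1-fold higher number from compound 2 to compound 4 (0.05 log units; within the scatter).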

Compound 4, solubility: 1.6 ug/mL
The estimate for compound 4 lay 1.1-fold (0.05 log units) above the measured number, within the range that was stated.
By their numbers in this assay, from the lowest: compounds 3, 2, 4 and 1 (each within the scatter of the next, the first and the last beyond it).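

In this assay the change from 4-chlorophenyl to 4-(methylsulfanyl)phenyl gives no change at the digits printed from compound 2 to compound 4 (within the scatter), so at this place on the aromatic ring, para to a large group, this read-out does not separate chloro from methylsulfanyl. Compound 4 also adds a comparison on the sulfur itself: methyl in place of trifluoromethyl gives a 1.6-fold higher number from compound 3 to compound 4 (0.20 log units; within the scatter), while 4-(methylsulfanyl)phenyl in place of 3-(trifluoromethyl)phenyl on the aromatic nitrogen gives a 1.3-fold lower number from compound 1 to compound 4 (0.12 log units; within the scatter), and neither step leaves the scatter. These steps record only the size of each change, and no separate measurement is available to account for them.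

Still open, as far as these compounds go, is whether a different kind of group at this same place, such as an amine or a carboxylic acid, would produce a step beyond the scatter. Also open, from the compounds shown here alone, is whether a longer chain on the sulfur, such as ethylsulfanyl, would stay within the scatter of compound 4, as the trifluoromethyl group on sulfur in compound 3 does.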